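The compounds below may be only part of what the source reports. "The series", "measured", "known", "first", "only" and "open" are said of these compounds alone.

Compound 1 `CCCCS(=O)(=O)NNC(=O)[C@@H](NC(=O)c1cccc(Cn2ccnc2)c1)[C@@H](C)CC` was tested in an assay on HEK293 cells for displacement of a labelled ligand from Type-2 angiotensin II receptor (Homo sapiens); a higher number here means a weaker inhibitor, a lower number a stronger inhibitor. In this assay compound 1 gives only > 100000 nM, which is a limit of the assay rather than a number (the limit of > 100000 nM in this assay, at which 1 of the 3 values shown sits). Compound 2 `CCCCS(=O)(=O)NC(=O)[C@@H](NC(=O)c1cccc(Cn2ccnc2)c1)[C@@H](C)CC`, carrying butylsulfonyl in place of (butylsulfonyl)amino on an amide-type nitrogen, gives 9900 nM in this assay, so the step of an at least 10-fold lower number from compound 1 to compound 2 (1.00 log units; beyond the scatter) is at least modest. Compound 3 `CC[C@H](C)[C@H](NC(=O)c1cccc(Cn2ccnc2)c1)C(N)=O` has "not determined" (no result reported) in this assay. Compound 4 `CC[C@H](C)[C@H](NC(=O)c1cccc(Cn2ccnc2)c1)C(=O)NNS(=O)(=O)c1ccc(OC)cc1` differs from compound 1 in a different way: 4-methoxyphenyl in place of butyl on a sulfonyl sulfur. Among the measured compounds shown here, no measured step follows an exchange of the group on the sulfonyl sulfur; the one measured step concerns the nitrogen bridge instead, and it does not transfer to this change. Compound 1 sits at a limit, so the starting point itself is uncertain. Compound 4 is therefore expected to remain weak, with an estimated step of an at least 1.6-fold lower number from compound 1 to compound 4 (0.22 log units; that floor lies within the scatter). The estimate for compound 4 is 60000 nM, with a likely range from 8000 nM to 300000 nM, and a real chance that this assay again reports only a limit.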

Compound 4, inhibition constant: 9200 nM
Estimate against measurement, compound 4: 6.5-fold (0.81 log units) above; low and high end bracket the measured number.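

Exchanging the group on the sulfonyl sulfur changes the result in this assay: putting 4-methoxyphenyl in place of butyl gives an at least 10-fold lower number from compound 1 to compound 4 (1.03 log units; beyond the scatter). Among the compounds shown here, the only earlier step concerned the nitrogen bridge, so this is the first sign that the group on the sulfur also matters while that bridge stays in place. The value of compound 1 is a limit, so the true size of this step stays unknown and the printed figure is only a floor: the limit of > 100000 nM in this assay, at which 1 of the 4 values shown sits.

The compounds shown leave open whether the change follows the aromatic ring itself or its methoxy group, a question that a plain phenyl or a 4-chlorophenyl on the sulfur would help to answer. As far as these compounds go, it also remains open whether 4-methoxyphenyl would act in the same way on compound 2, which lacks the nitrogen bridge.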